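Methoxyphenyl in place of dichlorophenyl in a flat series

The compounds below may be only part of what the source reports. "The series", "measured", "known", "first", "only" and "open" are said of these compounds alone.

Compound 1 `O=C(CCCc1ccccc1)Nc1nc2ccccc2c(=O)s1` is tested in an assay on CHO cells for displacement of a labelled ligand from adenosine receptor A3 (Homo sapiens), read by scintillation counting, with a stated time of 60 min; on this read-out lower numbers stand for stronger inhibition and higher numbers for weaker inhibition. In this assay compound 1 gives > 1000 nM, which is a limit of the assay and not a number. Compound 2 `O=C(CCCc1ccc(Cl)c(Cl)c1)Nc1nc2ccccc2c(=O)s1` gives > 1000 nM, again a limit. Compound 3 `O=C(CCCc1ccccc1)Nc1nc2sccc2c(=O)s1` gives > 1000 nM, also a limit. Going by the values given here, compound 2 thus stands at the limit of > 1000 nM in this assay, at which 3 of the 3 values shown sit, and the only single-change step measured, a step that the two limits leave unreadable from compound 1 to compound 2, carries no readable size or direction. Compound 4 `COc1cccc(CCCC(=O)Nc2nc3ccccc3c(=O)s2)c1` differs from compound 2 by 3-methoxyphenyl in place of 3,4-dichlorophenyl on a saturated chain carbon, three bonds along the chain from a carbonyl carbon. With no readable step to draw on, the estimated step that the limit leaves unreadable from compound 2 to compound 4 is expected to leave compound 4 near the same limit. Compound 4 is therefore expected to give about 2500 nM, with a range from 600 nM to 15000 nM.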

Compound 4, inhibition constant: 382 nM
Compound 4: middle estimate off by 6.5-fold (0.82 log units), on the high side; the whole stated range lies above it.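

Methoxy on the phenyl ring turns an unreadable series into a readable one: 3-methoxyphenyl in place of 3,4-dichlorophenyl gives an at least 2.6-fold lower number from compound 2 to compound 4 (0.41 log units; beyond the scatter), and methoxy in place of hydrogen on an aromatic carbon gives an at least 2.6-fold lower number from compound 1 to compound 4 (0.41 log units; beyond the scatter). The group at the end of the chain can therefore move this read-out, which the step from compound 1 to compound 2 could not show, as that step cannot be read. The other compounds remain at a limit, not a number: the limit of > 1000 nM in this assay, at which 3 of the 4 values shown sit.

Going by these compounds, the full size of both steps stays open, as each is only a lower bound. Also open, on these data alone, is whether an ethoxy or hydroxy group in place of methoxy, a longer chain, or the core of compound 3 would keep the lower number.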